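The compounds below may be only part of what the source reports. "The series", "measured", "known", "first", "only" and "open" are said of these compounds alone.

compound 1 `S=c1n(-c2ccccc2)c(=S)n2n1CCCC2` gives 7940 nM
compound 2 `S=c1n(-c2ccc(OCc3ccc(Cl)cc3)cc2)c(=S)n2n1CCCC2` gives 17.4 nM
compound 3 `CC(C)Oc1cc(/N=c2\sc(=S)n3n2CCCC3)c(F)cc1Cl` gives 13.8 nM

These values come from a functional assay on the whole organism for inhibition, with Scenedesmus acutus as the target (a higher number here means a weaker inhibitor, a lower number a stronger inhibitor), and offer only a small first picture. Compound 3 and compound 2 lie within the usual scatter of each other, and both have far lower numbers than compound 1. Compound 3 therefore belongs with the stronger inhibitors of this small set.

The next compound, not yet measured, is compound 4 `Fc1cc(Cl)ccc1/N=c1\sc(=S)n2n1CCCC2` and it carries a single change from compound 3. Hydrogen takes the place of isopropoxy on an aromatic carbon (hydrogen in place of isopropoxy on an aromatic carbon) and the rest of the structure stays the same.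

Among the measured compounds shown here, no measured pair differs in just one place, so nothing shows this step directly. The nearest hint is compound 1, whose aromatic ring carries no substituent and which gives 7940 nM as its number. Compound 2, with a substituted ring, gives 17.4 nM instead. Their core differs from that of compound 3, so this hint is weak.

A rise in the number beyond the scatter is still expected, which would mean a weaker inhibitor. The expected size of this change is a 36-fold higher number from compound 3 to compound 4 (1.56 log units; beyond the scatter) in this assay as estimated here. Compound 4 is estimated at 500 nM with 90 nM to 2800 nM as the expected range.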

Compound 4, half-maximal inhibitory concentration: 120 nM
Compound 4: middle estimate off by 4.2-fold (0.62 log units), on the high side; the range from low to high includes it.
By their numbers in this assay, from the lowest: compounds 3 and 2 (each within the scatter of the next); then compound 4; then compound 1.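

In this assay, among the compounds shown here, replacing the isopropoxy group with hydrogen gives an 8.7-fold higher number from compound 3 to compound 4 (0.94 log units; beyond the scatter), the first change in this set that can be read at a single place. It shows that the isopropoxy group on this aromatic carbon, ortho to the chloro group and para to the fluoro group, adds to inhibition in this series, since the step lies beyond the scatter. Even so, compound 4 gives 120 nM, so inhibition does not vanish when the isopropoxy group is gone, and this group is helpful here rather than essential. No measurement presented here explains why the isopropoxy group has this effect.

One replacement cannot separate the part played by the oxygen atom from that of the carbons attached to it, and a methoxy group, a hydroxyl group or a longer alkoxy chain on the same carbon would help to tell them apart. On these data alone, it also remains open whether an amine or a carboxylic acid could stand at this position, and how either would compare with the isopropoxy group of compound 3.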